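Methylating the hydroxy group of compound 1

The source may hold more compounds than are shown below. What is called first, only, known or untested is meant among the compounds shown, and "the series" means these compounds.

Values in a functional assay on PC-3 cells (Homo sapiens) for inhibition, read by sulforhodamine B assay, with a stated time of 48 h, tested at 1 uM; on this read-out higher numbers stand for a weaker effect at the one concentration tested and lower numbers for a stronger effect:
compound 1 `O=C(Nc1cccc(-n2cc(-c3ccncc3)c(-c3cc(O)cc(Cl)c3)n2)c1)Nc1ccc(Cl)c(C(F)(F)F)c1`: 83%
compound 2 `O=C(Nc1cccc(-n2cc(-c3ccncc3)c(-c3cc(O)cc(Cl)c3)n2)c1)Nc1ccc(Cl)c(Cl)c1`: 72%

Compound 1 stands highest of the two numbers; the nearest is compound 2, reached by a number 11 percentage points lower from compound 1 to compound 2 (beyond the scatter). Compound 3 `COc1cc(Cl)cc(-c2nn(-c3cccc(NC(=O)Nc4ccc(Cl)c(C(F)(F)F)c4)c3)cc2-c2ccncc2)c1` differs from compound 1 by methyl in place of hydrogen on an oxygen on an aromatic ring. Going by the values given here, no measured step touches this oxygen, so the single step from compound 1 to compound 2 does not bear on it; the expectation rests on compound 1 alone. A step of about a number 2 percentage points higher from compound 1 to compound 3 (within the scatter) is expected, no larger than the scatter. Compound 3 is estimated at 85%, between 70% and 100%.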

Compound 3, a percentage reported as activity, at one concentration (the size of the read-out at that concentration, not a potency): 14%
The estimate for compound 3 lay 71 percentage points above the measured number; measured number below the stated range.
By their numbers in this assay, from the lowest: compound 3; then compound 2; then compound 1.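

On the oxygen on the aromatic ring, hydroxy to methoxy is a large step in this assay (a number 69 percentage points lower from compound 1 to compound 3 (beyond the scatter)), and a stronger effect at the one concentration tested. This place responds far more than the other place varied so far, where chloro in place of trifluoromethyl gives a modest step (a number 11 percentage points lower from compound 1 to compound 2 (beyond the scatter)). No measurement on hand accounts for the step.

As far as these compounds go, whether the methyl itself matters or only the loss of the hydrogen stays open, and an ethoxy group or an amine at this place would help separate the two. Also open, from the compounds shown here alone, is whether the step carries over to compound 2.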